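The source may hold more compounds than are shown below. What is called first, only, known or untested is meant among the compounds shown, and "the series" means these compounds.

Measured in a functional assay on HCT-116 cells (Homo sapiens) for inhibition, read by CCK-8 assay, with a stated time of 48 h; on this read-out higher numbers stand for weaker inhibition and lower numbers for stronger inhibition:
- compound 1 `COc1ccc(CN(C(=O)CSC(=S)N2CCN(C(=O)OC(C)(C)C)CC2)c2cc(OC)c(OC)c(OC)c2)cc1`: 620 nM
- compound 2 `COc1ccc(CN(C(=O)CSC(=S)N2CCN(C(=O)OC(C)(C)C)CC2)c2ccc(Br)cc2)cc1`: > 20000 nM (a limit)
- compound 3 `COc1ccc(CN(C(=O)CSC(=S)N2CCN(C(=O)OC(C)(C)C)CC2)c2ccccc2)cc1`: > 20000 nM (a limit)

Compound 3 stands at > 20000 nM, which is a limit and not a number. Compound 4 `COc1ccc(CN(C(=O)CSC(=S)N2CCN(C(=O)OC(C)(C)C)CC2)c2ccc(C)cc2)cc1` differs from compound 3 by methyl in place of hydrogen on an aromatic carbon. The nearest measured change, on that same carbon, is a step that the two limits leave unreadable from compound 2 to compound 3. The large steps, an at least 32-fold higher number from compound 1 to compound 2 (1.50 log units; beyond the scatter) and an at least 32-fold higher number from compound 1 to compound 3 (1.50 log units; beyond the scatter), both start from compound 1 and concern a different replacement, so they suggest no recovery here. No step beyond the scatter is expected in this assay, and a further limit is likely. The expected change is a number no higher from compound 3 to compound 4 (the limit leaves the size open). For compound 4 the estimate is 20000 nM, with an expected range of 8000 nM to 40000 nM.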

Compound 4, half-maximal inhibitory concentration: > 20000 nM
Compound 4 ended at the assay's limit; the forecaster's own chance of this, stated with the estimate: 80%; the middle value lies on the limit itself.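

In this assay, 4-methylphenyl on the amide-type nitrogen is a third replacement of 3,4,5-trimethoxyphenyl that falls short of compound 1, with an at least 32-fold higher number from compound 1 to compound 4 (1.50 log units; beyond the scatter). The steps among compound 2, compound 3 and compound 4 cannot be read, so hydrogen, bromo and methyl on this carbon cannot be ranked. All three compounds share one limit: the limit of > 20000 nM in this assay, at which 3 of the 4 values shown sit.

Open, from the compounds shown here alone, is whether an amine such as dimethylamino on this carbon gives a readable value. Also open, going by these compounds, is which of the methoxy groups of compound 1 matter.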